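Swapping a Phenyl for a Cyclohexyl at the Carbonyl

The source may hold more compounds than are shown below. What is called first, only, known or untested is meant among the compounds shown, and "the series" means these compounds.

Of the compounds shown here, three sharing one core have been measured in a functional assay on cardiac atrium for agonist activity at histamine H2 receptor (Cavia porcellus); on this read-out lower numbers stand for smaller maximal responses and higher numbers for larger maximal responses. Compound 1 `N=C(NCCCc1c[nH]cn1)NCCC(c1ccc(F)cc1)c1ccccn1` gives 100% in this assay. Compound 2 `N=C(NCCCc1c[nH]cn1)NC(=O)CC(c1ccccc1)c1ccccn1` gives 97% in this assay. Compound 3 `N=C(NCCCc1c[nH]cn1)NC(=O)c1ccccc1` gives 89% in this assay, the lowest of the three numbers; its gap to compound 2 lies within the usual scatter of repeated measurements, while its gap to compound 1 lies beyond it.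

Compound 4 `N=C(NCCCc1c[nH]cn1)NC(=O)C1CCCCC1` has not yet been measured. It differs from compound 3 in one place: cyclohexyl in place of phenyl on a carbonyl carbon. Within the data shown here, no measured pair shows what this exchange does, and the other two compounds carry different side groups, so there is no direct guide. A ring-for-ring exchange of this kind, where an aromatic ring gives way to a non-aromatic one of the same size, is expected to move the largest response only modestly, if at all. The step of a number 4 percentage points lower from compound 3 to compound 4 (within the scatter) is expected to stay close to the scatter, with a slight lean downward. Compound 4 is therefore estimated at 85%, with a range from 70% to 100%.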

Compound 4, largest response reached (Emax), in percent of the reference or control that the assay uses: 102%
Compound 4: the middle estimate sits 17 percentage points below what was measured, outside the stated range (above it).
By their numbers in this assay, from the lowest: compounds 3, 2, 1 and 4 (each within the scatter of the next, the first and the last beyond it).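

Cyclohexyl in place of phenyl on a carbonyl carbon gives a number 13 percentage points higher from compound 3 to compound 4 (beyond the scatter) in this assay, the first measured exchange at this position. The ring here therefore need not be aromatic for the largest response to hold, and in this pair the non-aromatic ring of the same size gives the higher number. Nothing at hand shows why the response shifts with this exchange.

Still open, as far as these compounds go, is how far this position tolerates other groups on the carbonyl carbon, such as a cyclopentyl ring, an open tert-butyl group, or a longer chain ending in a cyclohexyl ring. From the compounds shown here alone, it is also open whether the same exchange of phenyl for cyclohexyl would act in the same direction in compounds with other side groups.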